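This account rests on a few compounds, and the source may have more. Where it says the series, first, only, none or still open, it means among the compounds named here.

Compound 1 `O=C1c2c[n+]([O-])c3ccccc3c2C(=O)c2c1c1ccccc1n2Cc1cn(C[C@H](O)CO)nn1` gives 1310 nM in a functional assay on MDA-MB-231 cells (Homo sapiens) for cytotoxicity, read by MTT assay, with a stated time of 72 h; on this read-out higher numbers stand for weaker inhibition and lower numbers for stronger inhibition.
Compound 2 `O=C1c2c[n+]([O-])c3ccccc3c2C(=O)c2c1c1ccccc1n2Cc1cn([C@@H]2O[C@H](CO)[C@@H](O)[C@H](O)[C@H]2O)nn1` gives 650 nM in this assay.

Compound 1 and compound 2 sit within the scatter of each other: a 2.0-fold lower number from compound 1 to compound 2 (0.30 log units; within the scatter). Compound 3 `CN1CCN(CCCCCn2c3c(c4ccccc42)C(=O)c2c[n+]([O-])c4ccccc4c2C3=O)CC1` differs from compound 1 by 4-(4-methylpiperazin-1-yl)butyl in place of 1-(2,3-dihydroxypropyl)-1H-1,2,3-triazol-4-yl on a saturated chain carbon bound to an aromatic nitrogen. Within the data shown here, the single measured step changes only the group on an aromatic nitrogen and leaves the rest of the side chain intact, so it does not bear on this replacement. Among the measured compounds shown here, with no step to lean on, compound 3 is expected near compound 1, a 1.5-fold lower number from compound 1 to compound 3 (0.16 log units; within the scatter), and the range is set wide. The estimate for compound 3 in this assay is 900 nM, between 200 nM and 4000 nM.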

Compound 3, half-maximal inhibitory concentration: 2270 nM
Beside the measured number, compound 3's estimate is 2.5-fold (0.40 log units) below it, within the range that was stated.
By their numbers in this assay, from the lowest: compounds 2, 1 and 3 (each within the scatter of the next, the first and the last beyond it).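

In this assay, 4-(4-methylpiperazin-1-yl)butyl in place of 1-(2,3-dihydroxypropyl)-1H-1,2,3-triazol-4-yl on a saturated chain carbon bound to an aromatic nitrogen gives a 1.7-fold higher number from compound 1 to compound 3 (0.24 log units; within the scatter). This place thus accepts a side chain without the five-membered aromatic ring, with 0 hydrogen-bond donors and no defined stereocentre, and the step stays within the scatter. Nothing measured here offers an explanation for this result.

Open, as far as these compounds go, is how a carboxylic acid or a primary amine at the end of the chain would read in this assay. Also open, from the compounds shown here alone, is the separate contribution of chain length and ring, as both differ together in compound 3.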